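The source may report more compounds than this note shows. Statements on the series, on what has been measured and on what is new or still open speak of the compounds shown alone.

The series shares the core of compound 1 `O=C(NCCCCCCSSCCCCCCNC(=O)c1cc(-c2ccncc2)n[nH]1)c1cc(-c2ccncc2)n[nH]1`, which in a functional assay on MDA-MB-231 cells (Homo sapiens) for inhibition, read by MTT assay, with a stated time of 96 h (a lower number here means a stronger inhibitor of growth, a higher number a weaker inhibitor of growth), gives 27300 nM. Compound 2 `CCCC(=O)SCCCCCCNC(=O)c1cc(-c2ccncc2)n[nH]1` carries a single thioester chain in place of the disulfide; in this assay compound 2 gives > 50000 nM, a limit of the assay and not a number. Compound 3 `CCCCCCCC/C=C\CCCCCCCC(=O)SCCCCCCNC(=O)c1cc(-c2ccncc2)n[nH]1` returns in this assay a reading of > 50000 nM, again a limit rather than a number. Compound 2 thus stands at the limit of > 50000 nM in this assay, at which 2 of the 3 values shown sit, alongside compound 3, with compound 1 the only one of the three to give a number. Compound 4 `CCC(=O)SCCCCCCNC(=O)c1cc(-c2ccncc2)n[nH]1` is not yet measured; it differs from compound 2 as hydrogen in place of methyl on a saturated chain carbon, two bonds along the chain from a carbonyl carbon. Among the compounds with values here, no step between measured compounds is available to calibrate such a change. A change of hydrogen in place of methyl on a saturated chain carbon, two bonds along the chain from a carbonyl carbon, is expected to move this assay by nothing beyond the scatter, so the step from compound 2 to compound 4 is expected to be a step that the limit leaves unreadable from compound 2 to compound 4 in either direction. Compound 4 is therefore estimated at 60000 nM, with a range of 25000 nM to 150000 nM, and most likely reported again as a limit.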

Compound 4, concentration for 50% growth inhibition: > 50000 nM
Compound 4: only a limit was reported; the forecaster's own chance of this, stated with the estimate: 80%; the middle value lies beyond the limit too.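

No step can be read between compound 2 and compound 4, as both readings are limits of the assay and not numbers, and the two sit at the same one: the limit of > 50000 nM in this assay, at which 3 of the 4 values shown sit.

The compounds shown leave open how the length of the thioester chain bears on growth inhibition, with no thioester here giving a number.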